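The source may hold more compounds than are shown below. What is called first, only, known or untested is meant among the compounds shown, and "the series" means these compounds.

Series notes, cytotoxicity set.

- Compound 1 `Cc1cccc(Cn2cc(COc3ccc4c(=O)ccoc4c3)nn2)c1` gives in an ADME assay on L02 cells (Homo sapiens) for cytotoxicity, read by MTT assay, with a stated time of 48 h (on this read-out higher numbers stand for weaker inhibition and lower numbers for stronger inhibition), only a limit, > 300000 nM.
- Compound 2 `Cc1ccccc1Cn1cc(COc2ccc3c(=O)ccoc3c2)nn1` gives in this assay only a limit, > 300000 nM.
- Compound 3 `O=c1ccoc2cc(OCc3cn(Cc4cccc([N+](=O)[O-])c4)nn3)ccc12` gives in this assay only a limit, > 300000 nM.

Compound 3 therefore stands at the limit of this assay, and no order among the three measured compounds can be read: the limit of > 300000 nM in this assay, at which 3 of the 3 values shown sit. Within the data shown here, for the same reason the steps a step that the two limits leave unreadable from compound 1 to compound 2, a step that the two limits leave unreadable from compound 1 to compound 3 and a step that the two limits leave unreadable from compound 2 to compound 3 cannot be sized; they show only that each change left the compound beyond the limit.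

Compound 4 `N#Cc1cccc(Cn2cc(COc3ccc4c(=O)ccoc4c3)nn2)c1` is the next to be measured in this assay. It differs from compound 3 by cyano in place of nitro on an aromatic carbon. Among the measured compounds shown here, the steps that bear on this change are the two ending at compound 3, a step that the two limits leave unreadable from compound 1 to compound 3 and a step that the two limits leave unreadable from compound 2 to compound 3, and both are unreadable; nothing measured here distinguishes nitro from methyl, and cyano has no precedent in the set.

Compound 4 is expected to sit beyond the limit as well, with a step that the limit leaves unreadable from compound 3 to compound 4 expected, given that every value shown sits at the limit (the limit of > 300000 nM in this assay, at which 3 of the 3 values shown sit). Compound 4 is estimated at 400000 nM, with a range from 150000 nM to 1000000 nM.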

Compound 4, half-maximal inhibitory concentration: > 300000 nM
Compound 4 gave a limit, no number; the forecaster's own chance of this, stated with the estimate: 85%; the middle value is on the limit's open side.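

Compound 4, like compound 1, compound 2 and compound 3, gives only a limit in this assay, so no new step among them can be read: the limit of > 300000 nM in this assay, at which 4 of the 4 values shown sit.

The compounds shown leave open how methyl, nitro and cyano compare in this assay, and at what concentration any of these four compounds would reach half-maximal inhibition.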